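The source may report more compounds than this note shows. Statements on the series, on what has been measured and on what is new or still open speak of the compounds shown alone.

Measured so far:
compound 1 `COc1cc(-c2cc(/C=C/C(=O)c3ccc(Cl)c(Cl)c3)[nH]n2)cc(OC)c1OC`, 98%
compound 2 `COc1ccc(-c2cc(/C=C/C(=O)c3cc(OC)c(OC)c(OC)c3)[nH]n2)cc1OC`, 97%

Both compounds were tested in a functional assay on IGROV-1 cells (Homo sapiens) for cytotoxicity, read by sulforhodamine B assay, with a stated time of 48 h, tested at 0.1 uM; a lower number here means a stronger effect, a higher number a weaker effect of the compound at the concentration tested. Compound 1 gives 98%, and compound 2 gives 97%; the gap between the two numbers lies within the usual scatter of such measurements, so neither compound can be set apart from the other, and both sit close to the level of cells left untreated. Going by the values given here, no step between two measured compounds that differ in a single place is available.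

Compound 3 `COc1ccc(C(=O)/C=C/c2cc(-c3cc(OC)c(OC)c(OC)c3)n[nH]2)cc1OC` is the next compound and has not yet been measured. It differs from compound 1 in one place: 3,4-dimethoxyphenyl in place of 3,4-dichlorophenyl on a carbonyl carbon. Since compound 1 and compound 2 both show almost no effect in this assay, and compound 2 already carries methoxy-bearing rings at both ends, no step beyond the scatter is expected from compound 1 to compound 3, and compound 3 is expected to show a number 1 percentage points lower from compound 1 to compound 3 (within the scatter). Compound 3 is therefore estimated at 97%, with a range from 88% to 104%.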

Compound 3, a percentage reported as activity, at one concentration (the size of the read-out at that concentration, not a potency): 96%
For compound 3 the middle estimate is 1 percentage points above the measured one; measured number inside the range.
By their numbers in this assay, from the lowest: compounds 3, 2 and 1 (each within the scatter of the next).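

Going by these compounds alone, compound 1 and compound 3 form the first pair that differs in a single place, and in this assay the swap of 3,4-dichlorophenyl for 3,4-dimethoxyphenyl on a carbonyl carbon gives a number 2 percentage points lower from compound 1 to compound 3 (within the scatter), which is no real change. This place therefore accepts a larger group with 2 hydrogen-bond acceptors instead of 0 without moving the read-out, though all three compounds remain close to untreated cells, so this flat result says little about what would raise activity. No separate measurement is available to explain it.

Going by these compounds, whether a phenyl ring carrying an amine or a carboxylic acid at this place would move the number remains open. So does whether compound 1 and compound 3 would separate at a concentration where the cells clearly respond.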